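A few compounds are considered here, and "the series" means these few. Any claim that something is new, unique, unknown or untested is made for them only; others in the source may bear on it.

Measured so far:
- compound 1 `CNc1ccc(C(=O)Oc2cc(O/N=[N+](\[O-])N(C)C)c([N+](=O)[O-])cc2[N+](=O)[O-])cc1`: 2600 nM
- compound 2 `CN(C)/[N+]([O-])=N/Oc1cc(Nc2ccc(C(=O)O)cc2)c([N+](=O)[O-])cc1[N+](=O)[O-]`: 100000 nM

In a functional assay on OVCAR-3 cells (Homo sapiens) for cytotoxicity (on this read-out lower numbers stand for higher toxicity in this test and higher numbers for lower toxicity in this test), compound 2 gives 100000 nM, the higher of the two numbers in hand. Compound 1 gives 2600 nM in this assay, a lower number, and the gap between the two is beyond the scatter; no single-point comparison links them, so only the two values themselves can be set side by side.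

The next compound, compound 3 `CN(C)/[N+]([O-])=N/Oc1cc(Nc2cccc(C(=O)O)c2)c([N+](=O)[O-])cc1[N+](=O)[O-]`, is not yet measured. It differs from compound 2 in one place: 3-carboxyphenyl in place of 4-carboxyphenyl on a nitrogen on an aromatic ring. For the measured compounds named here, the two carboxyphenyl groups match in everything that is counted, so no step between measured compounds offers a guide to what this rearrangement does. The step of a 1.3-fold lower number from compound 2 to compound 3 (0.10 log units; within the scatter) is expected to be small, within the scatter, with no firm direction. Compound 3 is therefore estimated at 80000 nM, in a range from 25000 nM to 250000 nM.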

Compound 3, concentration lethal to 50% of the cells in the OVCAR-3 assay: 58000 nM
For compound 3 the middle estimate is 1.4-fold (0.14 log units) above the measured one; the measured number falls inside the stated range.
By their numbers in the OVCAR-3 assay, from the lowest: compound 1; then compounds 3 and 2 (each within the scatter of the next).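

Exchanging 4-carboxyphenyl for 3-carboxyphenyl on a nitrogen on an aromatic ring gives, in the OVCAR-3 assay, a 1.7-fold lower number from compound 2 to compound 3 (0.24 log units; within the scatter), so at this place the two arrangements of the carboxyphenyl group cannot be told apart in this test. In a physicochemical assay for solubility, in phosphate buffer, at 37 degrees C (a lower number here means a less soluble compound, a higher number a more soluble compound), compound 2 gives > 3000000 nM, which is a limit of the assay and not a number. In the physicochemical assay compound 3 gives > 2000000 nM, which is likewise a limit.

The step between these two limits cannot be read, and nothing in hand accounts for the small step in the OVCAR-3 assay. On these data alone, it stays open how the OVCAR-3 assay would respond if an amide or a sulfonic acid took the place of the carboxylic acid on this phenyl group.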